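Side-chain change from compound 2 to compound 3

A few compounds are considered here, and "the series" means these few. Any claim that something is new, unique, unknown or untested is made for them only; others in the source may bear on it.

In a functional assay (trachea) with Cavia porcellus as the target (a lower number here means that less compound is needed, a higher number that more compound is needed for the effect), compound 1 (`CCCn1c(=O)n(CCC(N)=O)c(=O)c2[nH]cnc21`) gives 13100 nM and compound 2 (`CCCn1c(=O)n(CCCO)c(=O)c2[nH]cnc21`) gives 5100 nM as the lower of the two numbers. Compound 3 (`CCCn1c(=O)n(CCOCC)c(=O)c2[nH]cnc21`) carries ethoxy in place of hydroxymethyl on a saturated chain carbon, two bonds along the chain from an aromatic nitrogen. Among the measured compounds shown here, the one measured step at this place is a 2.6-fold lower number from compound 1 to compound 2 (0.41 log units; beyond the scatter) and it was modest. A different group entered there, so it fixes no direction here. In this assay a step no larger than that one is expected, probably within the scatter. The expected change is a 1.3-fold lower number from compound 2 to compound 3 (0.11 log units; within the scatter) and it stays small. Compound 3 is estimated at 4000 nM (range 1500 nM to 11000 nM).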

Compound 3, half-maximal effective concentration: 70 nM
The estimate for compound 3 lay 57-fold (1.76 log units) above the measured number; measured number below the stated range.
By their numbers in this assay, from the lowest: compound 3; then compound 2; then compound 1.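

Going from 3-hydroxypropyl to 2-ethoxyethyl gives a 73-fold lower number from compound 2 to compound 3 (1.86 log units; beyond the scatter) in this assay and so shows that this chain position can move the number far more than the earlier step suggested. Against the carbamoyl chain, the ethoxy chain gives a 190-fold lower number from compound 1 to compound 3 (2.27 log units; beyond the scatter) in the same read-out. Nothing available here accounts for the size of this change.

The compounds shown do not separate the part played by the ether oxygen from that of the terminal ethyl or the lost hydroxyl hydrogen. A methoxy ether or an all-carbon pentyl chain at this place would bear on that.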